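Cyclohexenyl-methyl group replacing aminocyclohexyl in compound 3

The compounds below may be only part of what the source reports. "The series", "measured", "known", "first", "only" and "open" are said of these compounds alone.

Compound 3 `N[C@H]1CC[C@@H](N(C[C@H]2Cc3ccccc3CN2)[C@H]2CCCc3cccnc32)CC1` stands highest of the three numbers in a functional assay on CCRF-CEM cells for antagonist activity at C-X-C chemokine receptor type 4 (Homo sapiens), read by calcium flux, with stated times of 25 min and 90 s (a higher number here means a weaker inhibitor, a lower number a stronger inhibitor), where compound 3 gives 1800 nM. Compound 1 `C/C(CN)=C(/F)CN(C[C@H]1Cc2ccccc2CN1)[C@H]1CCCc2cccnc21` gives 44 nM and compound 2 `C/C(=C/CN)CN(C[C@H]1Cc2ccccc2CN1)[C@H]1CCCc2cccnc21` gives 28 nM. Compound 4 `NCC1=C(CN(C[C@H]2Cc3ccccc3CN2)[C@H]2CCCc3cccnc32)CCCC1` differs from compound 3 by (2-(aminomethyl)cyclohex-1-en-1-yl)methyl in place of 4-aminocyclohexyl on an amine nitrogen. The entering group carries an aminomethyl and a double bond outside aromatic rings, features that compound 1 and compound 2 also carry, while a six-membered ring is kept. The steps of a 41-fold higher number from compound 1 to compound 3 (1.61 log units; beyond the scatter) and a 64-fold higher number from compound 2 to compound 3 (1.81 log units; beyond the scatter) bear on this, both large and both rising towards compound 3. Among the compounds with values here, a large step downward in this assay is therefore expected, though the ring of compound 4 has no measured counterpart here. Compound 4 is estimated at 70 nM, within 20 nM to 300 nM. The expected step is a 26-fold lower number from compound 3 to compound 4 (1.41 log units; beyond the scatter).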

Compound 4, half-maximal inhibitory concentration: 230 nM
For compound 4 the middle estimate is 3.3-fold (0.52 log units) below the measured one, within the range that was stated.
By their numbers in this assay, from the lowest: compounds 2 and 1 (each within the scatter of the next); then compound 4; then compound 3.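

In this assay, the result is a 7.8-fold lower number from compound 3 to compound 4 (0.89 log units; beyond the scatter), so a six-membered ring on this amine nitrogen reads better as (2-(aminomethyl)cyclohex-1-en-1-yl)methyl than as 4-aminocyclohexyl. The open-chain groups still read lower, with an 8.2-fold higher number from compound 2 to compound 4 (0.91 log units; beyond the scatter) and a 5.2-fold higher number from compound 1 to compound 4 (0.72 log units; beyond the scatter), so this ring in place of the open chain carries a cost. No evidence at hand explains these steps.

Open, on these data alone, is how a cyclopentene ring in place of the cyclohexene ring would read. Equally open, as far as these compounds go, is the effect of an aminoethyl group or a methylaminomethyl group in place of the aminomethyl.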